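A few compounds are considered here, and "the series" means these few. Any claim that something is new, unique, unknown or untested is made for them only; others in the source may bear on it.

Series notes. Compound 1 `C=C1C(n2cc(F)c(=O)[nH]c2=O)O[C@H](CO)[C@@H]1O`, compound 2 `C=C1C(n2cc(Br)c(=O)[nH]c2=O)O[C@H](CO)[C@@H]1O` and compound 3 `C=C1C(n2cc(I)c(=O)[nH]c2=O)O[C@H](CO)[C@@H]1O` share one core and differ only in the halogen on the aromatic carbon of the six-membered ring with 2 nitrogen. In a functional assay on L1210 cells (Mus musculus) for cytotoxicity (a higher number here means a weaker inhibitor, a lower number a stronger inhibitor), compound 1 gives > 100 ug/mL, which is a limit of the assay and not a number. Compound 2 in this assay gives > 100 ug/mL, again a limit. Compound 3 in this assay gives > 100 ug/mL, also a limit. All three values shown sit at the limit of > 100 ug/mL in this assay, at which 3 of the 3 values shown sit. The steps a step that the two limits leave unreadable from compound 1 to compound 2, a step that the two limits leave unreadable from compound 1 to compound 3 and a step that the two limits leave unreadable from compound 2 to compound 3 accordingly carry no readable size and no direction.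

Compound 4 `C#Cc1cn(C2O[C@H](CO)[C@H](O)C2=C)c(=O)[nH]c1=O` differs from compound 3 by ethynyl in place of iodo on an aromatic carbon. Going by the values given here, the three measured steps are the only ones that bear on this change, and none of them fixes a size; the exchange of iodo for ethynyl has no measured counterpart. The step from compound 3 to compound 4 is therefore expected to be a number no higher from compound 3 to compound 4 (the limit leaves the size open), with a limit rather than a number the most probable outcome. Compound 4 is estimated to give 100 ug/mL in this assay, within a range from 20 ug/mL to 300 ug/mL, and the result may well again be reported only as a limit.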

Compound 4, half-maximal inhibitory concentration: > 100 ug/mL
Compound 4: a limit, no number; the forecaster's own chance of this, stated with the estimate: 65%; the middle value sits exactly at the limit.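

In this assay compound 4 gives > 100 ug/mL, a limit of the assay and not a number, so no step from compound 1, compound 2 or compound 3 to compound 4 can be read: the limit of > 100 ug/mL in this assay, at which 4 of the 4 values shown sit.

The compounds shown leave open whether fluoro, bromo, iodo and ethynyl differ at all in this read-out, and in which direction.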